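A few compounds are considered here, and "the series" means these few. Any claim that something is new, unique, unknown or untested is made for them only; others in the source may bear on it.

Compound 1 `NC(=O)c1c(NC(=O)c2ccccc2Cl)sc2c1CCN(Cc1ccc([N+](=O)[O-])cc1)C2`: 46100 nM
Compound 2 `Cc1ccc(C(=O)Nc2sc3c(c2C(N)=O)CCN(Cc2ccc(Cl)cc2Cl)C3)cc1`: > 50000 nM
Compound 3 `NC(=O)c1c(NC(=O)c2ccccc2F)sc2c1CCN(Cc1ccc(Cl)cc1Cl)C2`: 27500 nM

In a functional assay on HeLa cells (Homo sapiens) for antiproliferative activity, with a stated time of 24 h (a lower number here means a stronger inhibitor, a higher number a weaker inhibitor), compound 1 gives 46100 nM, the higher of the two numbers shown; the nearest is compound 3, and the gap between them lies within the scatter. Compound 2 reaches only a limit of the assay, > 50000 nM. Compound 4 `NC(=O)c1c(NC(=O)c2ccccc2Cl)sc2c1CCN(C(=S)Nc1ccccc1I)C2` differs from compound 1 in one place: a group of 10 heavy atoms (7 carbon, 1 nitrogen, 1 sulfur, 1 iodine; one six-membered aromatic ring of carbon only) in place of a group of 10 heavy atoms (7 carbon, 1 nitrogen, 2 oxygen; one six-membered aromatic ring of carbon only), on an amine nitrogen in a ring. Among the measured compounds shown here, the only measured step, an at least 1.8-fold lower number from compound 2 to compound 3 (0.25 log units; that floor lies within the scatter), changes a group on a carbonyl carbon rather than on the amine nitrogen in the ring, and it stays within the scatter. For the measured compounds named here, no measured step touches the place changed here, so no direction can be drawn. Compound 4 is therefore expected to stay close to compound 1, with a 1.2-fold lower number from compound 1 to compound 4 (0.06 log units; within the scatter) expected to fall within the scatter. The estimate for compound 4 is 40000 nM, with a range from 15000 nM to 100000 nM.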

Compound 4, half-maximal inhibitory concentration: 29000 nM
Beside the measured number, compound 4's estimate is 1.4-fold (0.14 log units) above it; low and high end bracket the measured number.
By their numbers in this assay, from the lowest: compounds 3, 4 and 1 (each within the scatter of the next). At a limit, above all of these: compound 2.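

In this assay, among the compounds shown here, the one measured change on the amine nitrogen in a ring gives a 1.6-fold lower number from compound 1 to compound 4 (0.20 log units; within the scatter). For the compounds shown here, the position thus takes either 4-nitrobenzyl or the group carrying sulfur and iodine with no difference beyond the scatter, and the earlier compounds could not show this. Nothing measured here explains this result.

As far as these compounds go, it remains open whether a simple amine or a carboxylic acid on a longer chain at this nitrogen would move the number beyond the scatter. From the compounds shown here alone, whether the same swap behaves alike with other groups on the carbonyl carbon also remains open.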